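A few compounds are considered here, and "the series" means these few. Any claim that something is new, unique, unknown or untested is made for them only; others in the source may bear on it.

Compound 1 `CC1(c2ccccc2)CC(=O)N(CC(=O)N2CCN(c3ccccc3Cl)CC2)C1=O` gives 100 mg/kg in a functional assay on the whole organism (strain CD-1) with Mus musculus as the target, with a stated time of 2 h; a lower number here means that less compound is needed, a higher number that more compound is needed for the effect. Compound 2 `CC1(c2ccccc2)CC(=O)N(CC(=O)N2CCN(c3cccc(Cl)c3)CC2)C1=O` gives "not active" (no number reported) in this assay. Compound 3 `COc1cccc(N2CCN(C(=O)CN3C(=O)CC(C)(c4ccccc4)C3=O)CC2)c1` gives "not active" (no number reported) in this assay.

Compound 3 stands without a number in this assay: it is reported as inactive, and compound 2 is reported in the same way, so among the three measured compounds only compound 1 gives a minimum effective dose. For the measured compounds named here, no step between two measured compounds is available from these data, since no pair differs in a single place.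

Compound 4 `CC1(c2ccccc2)CC(=O)N(CC(=O)N2CCN(c3cccc(Cl)c3Cl)CC2)C1=O` is the unmeasured compound. Its change from compound 3 is 2,3-dichlorophenyl in place of 3-methoxyphenyl on an amine nitrogen in a ring. Going by the values given here, since compound 3 carries no number in this assay, no computed step can be given for this change; what can be said is that compound 1, the only active compound, also carries chlorine on the aromatic ring that enters here, whereas compound 2 with a chlorine on that ring is inactive. The expected outcome therefore ranges from inactivity to a dose near that of compound 1. Compound 4 is estimated to give 100 mg/kg in this assay, expected between 30 mg/kg and 300 mg/kg, with a substantial chance that only inactivity is reported.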

Compound 4, minimum effective dose: "not active" (no number reported)
The entry for compound 4 holds no number; there is nothing to compare the estimate with.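

In this assay compound 4, like compound 3, is reported as not active, so no step can be read between them. No further data bear on this result. The compounds shown leave open how the substitution on the aromatic ring relates to the activity of compound 1, the only one with a number.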